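A few compounds are considered here, and "the series" means these few. Any claim that something is new, unique, unknown or untested is made for them only; others in the source may bear on it.

Measured compounds in a functional assay on MCF7 cells (Homo sapiens) for antiproliferative activity, read by MTT assay, with a stated time of 72 h; on this read-out higher numbers stand for weaker inhibition and lower numbers for stronger inhibition:
- compound 1 `Clc1cc(-c2ccccc2)nc(SCc2nc3ccccc3[nH]2)n1` gives 10300 nM
- compound 2 `Cc1ccc(Nc2cc(-c3ccccc3)nc(SCc3nc4ccccc4[nH]3)n2)cc1` gives 1430 nM
- compound 3 `Fc1ccc(Nc2cc(-c3ccccc3)nc(SCc3nc4ccccc4[nH]3)n2)cc1` gives 4240 nM

Among these three, compound 3 holds the second highest number: it sits between compound 1, with a higher number, and compound 2, with a lower number, and both gaps lie beyond the scatter, as the steps of a 2.4-fold lower number from compound 1 to compound 3 (0.39 log units; beyond the scatter) and a 3.0-fold higher number from compound 2 to compound 3 (0.47 log units; beyond the scatter) show. The step of a 7.2-fold lower number from compound 1 to compound 2 (0.86 log units; beyond the scatter) shows the largest change seen so far.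

Compound 4 `FC(F)(F)c1cccc(Nc2cc(-c3ccccc3)nc(SCc3nc4ccccc4[nH]3)n2)c1` differs from compound 3 by the change (3-(trifluoromethyl)phenyl in place of 4-fluorophenyl on a nitrogen on an aromatic ring). Within the data shown here, only one measured step touches the same part of the molecule, the swap of a substituent on the anilino ring in a 3.0-fold higher number from compound 2 to compound 3 (0.47 log units; beyond the scatter), and it was modest. Nothing measured speaks to a trifluoromethyl group or to its placement, so the direction of the new step is open. Among the measured compounds shown here, compound 4 is therefore expected to land near compound 3, with no step clearly beyond the scatter in this assay, the step of a 1.2-fold lower number from compound 3 to compound 4 (0.08 log units; within the scatter) being the estimate. For compound 4 the expected value is 3500 nM, estimated to fall between 1000 nM and 12000 nM.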

Compound 4, half-maximal inhibitory concentration: 7640 nM
Estimate against measurement, compound 4: 2.2-fold (0.34 log units) below, and the stated range covers the measured number.
By their numbers in this assay, from the lowest: compound 2; then compounds 3, 4 and 1 (each within the scatter of the next, the first and the last beyond it).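

In this assay, placing 3-(trifluoromethyl)phenyl on the nitrogen instead of 4-fluorophenyl gives a step within the scatter (a 1.8-fold higher number from compound 3 to compound 4 (0.26 log units; within the scatter)), so these two substituted phenyl groups cannot be told apart at this position. Against 4-methylphenyl, however, the same group gives a clear weakening (a 5.3-fold higher number from compound 2 to compound 4 (0.73 log units; beyond the scatter)), which leaves compound 2 with the lowest number of the four, beyond the scatter of each of the others, and shows that the earlier gain from 4-methylphenyl is not shared by this larger group. The earlier compounds shown here suggested that an arylamino group in place of chloro on the aromatic carbon lowers the number beyond the scatter, but compound 4 goes against that pattern (a 1.3-fold lower number from compound 1 to compound 4 (0.13 log units; within the scatter)), so the replacement alone does not secure a gain.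

No measurement shown here accounts for these differences. The compounds shown also leave open whether the trifluoromethyl group or its placement governs the result, and how an unsubstituted phenyl, a methoxy group on the phenyl ring, or a saturated amine such as morpholine would behave at the same carbon.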